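Trimethoxyphenyl ureas and amides: nitro replacing fluoro

This account rests on a few compounds, and the source may have more. Where it says the series, first, only, none or still open, it means among the compounds named here.

Measured compounds:
compound 1, `COc1cc(N(C)C(=O)N(C)c2cccc([N+](=O)[O-])c2)cc(OC)c1OC`: >= 125000 nM in a functional assay on Daoy cells (Homo sapiens) for cytotoxicity, read by MTT assay, with a stated time of 72 h; on this read-out lower numbers stand for stronger inhibition and higher numbers for weaker inhibition
compound 2, `COc1cc(N(C)C(=O)N(C)c2cccc(F)c2)cc(OC)c1OC`: >= 125000 nM in this assay
compound 3, `COc1cc(N(C)C(=O)c2ccc(F)cc2)cc(OC)c1OC`: >= 125000 nM in this assay

Each of these three values is a limit of the assay and not a number. For compound 1 the value is a limit. For compound 2 the value is a limit. For compound 3 the value is a limit. The step that the two limits leave unreadable from compound 2 to compound 1 is therefore unreadable because of the limit of >= 125000 nM in this assay, at which 3 of the 3 values shown sit. The change it makes is nitro in place of fluoro on an aromatic carbon. Compound 4, `COc1cc(N(C)C(=O)c2ccc([N+](=O)[O-])cc2)cc(OC)c1OC`, carries the same kind of change relative to compound 3, namely (nitro in place of fluoro on an aromatic carbon); the place differs in that the new group sits meta to a large group in compound 1 but para to a large group in compound 4. The difference between the cores of compound 2 and compound 3 is not broken down here. Since compound 3 sits at the limit, and the earlier step from compound 2 to compound 1 gave no readable size, compound 4 is expected to give 125000 nM, a step of a number no higher from compound 3 to compound 4 (the limit leaves the size open), most likely again reported only as a limit.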

Compound 4, half-maximal inhibitory concentration: >= 125000 nM
Compound 4: only a limit was reported; the forecaster's own chance of this, stated with the estimate: 85%; the middle value sits exactly at the limit.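

No new step can be read from compound 4: its value and that of compound 3 are both limits, so the change from compound 3 to compound 4 has no readable size, because of this: the limit of >= 125000 nM in this assay, at which 4 of the 4 values shown sit.

The compounds shown leave open whether nitro in place of fluoro on an aromatic carbon makes any difference in this assay.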